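The source may hold more compounds than are shown below. What is called first, only, known or untested is meant among the compounds shown, and "the series" means these compounds.

Among the measured compounds shown here, compound 2 `CCCCCCCN1C(=O)[C@H](Cc2ccc(-c3cc(OC)c(OC)c(OC)c3)cc2)N(C)C(=O)[C@@H]1C` gives the lower of the two numbers so far: in a functional assay for agonist activity at follicle-stimulating hormone receptor (Homo sapiens), read by a luciferase reporter (on this read-out lower numbers stand for an effect already at smaller amounts and higher numbers for an effect only at larger amounts of compound), compound 2 gives 25 nM, against compound 1 `CCCCCCN1C(=O)[C@H](Cc2ccc(-c3cc(OC)c(OC)c(OC)c3)cc2)N(C)C(=O)[C@@H]1C`, which in this assay gives 100 nM. For the measured compounds named here, the one measured step, a 4.0-fold lower number from compound 1 to compound 2 (0.60 log units; beyond the scatter), came from a methyl in place of hydrogen on a saturated chain carbon, six bonds along the chain from the amide-type nitrogen in the ring. Compound 3 `CCCCCCCCN1C(=O)[C@H](Cc2ccc(-c3cc(OC)c(OC)c(OC)c3)cc2)N(C)C(=O)[C@@H]1C` carries the same kind of change one bond further out: methyl in place of hydrogen on a saturated chain carbon, seven bonds along the chain from an amide-type nitrogen in a ring. That earlier step bears directly on it, though a single step is no trend; a smaller further lowering, or none beyond the scatter, is expected, giving a 1.7-fold lower number from compound 2 to compound 3 (0.22 log units; within the scatter). Compound 3 is therefore estimated at 15 nM in this assay, within 5 nM to 50 nM.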

Compound 3, half-maximal effective concentration: 13 nM
For compound 3 the middle estimate is 1.2-fold (0.06 log units) above the measured one; the measured number falls inside the stated range.
By their numbers in this assay, from the lowest: compounds 3 and 2 (each within the scatter of the next); then compound 1.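

In this assay the added methyl on the saturated chain carbon, seven bonds along the chain from the amide-type nitrogen in the ring, gives a 1.9-fold lower number from compound 2 to compound 3 (0.28 log units; within the scatter) and so does not separate from no change. Read as one change, ethyl in place of hydrogen on the carbon six bonds along gives a 7.7-fold lower number from compound 1 to compound 3 (0.89 log units; beyond the scatter) and stays beyond the scatter. No evidence to hand accounts for either step.

From the compounds shown here alone, whether a longer chain lowers the number further remains open. So does how a chain ending in an amine or a carboxylic acid would read.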